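Swapping 4-methoxyphenyl for 2-methoxyphenyl: a small step expected

This account rests on a few compounds, and the source may have more. Where it says the series, first, only, none or still open, it means among the compounds named here.

In a functional assay on HepG2 cells (Homo sapiens) for antiproliferative activity, read by MTT assay, with a stated time of 24 h (on this read-out lower numbers stand for stronger inhibition and higher numbers for weaker inhibition), compound 1 `c1ccc(Cc2nnc(Cn3nnc4ccccc43)o2)cc1` gives 369000 nM. Compound 2 `COc1ccc(Cc2nnc(Cn3nnc4ccccc43)o2)cc1`, which carries a methoxy in place of hydrogen on an aromatic carbon, gives 357000 nM. Within the data shown here, these are the only two numbers so far, and they stand level within the scatter, so neither can be called the better compound.

The next compound to test is compound 3 `COc1ccccc1Cc1nnc(Cn2nnc3ccccc32)o1`. It has the same atoms as compound 2, joined differently: 2-methoxyphenyl in place of 4-methoxyphenyl on a saturated chain carbon bound to an aromatic carbon. Among the measured compounds shown here, only one measured step bears on this change, the one that brought the methoxy in, a 1.0-fold lower number from compound 1 to compound 2 (0.01 log units; within the scatter). That step lies within the scatter. For the measured compounds named here, no measured compound yet carries 2-methoxyphenyl, so this is a thin guide and the range must stay wide. Going by the values given here, with compound 2 at 357000 nM and that small step as the only evidence, no shift beyond the scatter is expected in this assay. The expected step is a 1.0-fold lower number from compound 2 to compound 3 (0.01 log units; within the scatter), with no firm direction. For compound 3 the estimated value is 350000 nM, with an expected range from 170000 nM to 600000 nM.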

Compound 3, half-maximal inhibitory concentration: 334000 nM
Beside the measured number, compound 3's estimate is 1.0-fold (0.02 log units) above it, within the range that was stated.
By their numbers in this assay, from the lowest: compounds 3, 2 and 1 (each within the scatter of the next).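

Moving the methoxy from 4-methoxyphenyl to 2-methoxyphenyl, on a saturated chain carbon bound to an aromatic carbon, gives a 1.1-fold lower number from compound 2 to compound 3 (0.03 log units; within the scatter) in this assay and so reveals no difference between these two placements. The comparison with the compound that has no methoxy at all gives a 1.1-fold lower number from compound 1 to compound 3 (0.04 log units; within the scatter) and so agrees with the earlier step: with either placement, adding the methoxy brings no change that can be told apart from ordinary variation between repeated measurements. This is a useful finding for a newcomer, since a change in structure need not produce a readable change in a cell assay, but nothing available here explains this flat picture.

Still open, going by these compounds, is whether a group of a different kind on the aromatic ring, such as an amine, a carboxylic acid or a chlorine atom, would move the number beyond the scatter. Also open, on these data alone, is whether a longer chain in place of the saturated chain carbon would do so, and whether these three compounds would stay level on other cell lines.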